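The source may report more compounds than this note shows. Statements on the series, on what has been measured and on what is new or still open speak of the compounds shown alone.

Measured so far in a functional assay for inhibition, with Homo sapiens as the target; on this read-out higher numbers stand for weaker inhibition and lower numbers for stronger inhibition:
compound 1 `CN(C)c1ccc(Nc2nccc(-c3ccco3)n2)cc1` gives 1900 nM
compound 2 `Cc1ccsc1-c1ccnc(Nc2ccc(N(C)C)cc2)n1` gives 1800 nM
compound 3 `CC1CCN(c2ccc(Nc3nccc(-c4cccs4)n3)cc2)CC1` gives 400 nM

Compound 3 stands lowest of the three numbers; the nearest is compound 2, and the furthest is compound 1, both of them beyond the scatter. The step to compound 4 `CN(C)c1ccc(Nc2nccc(-c3cccs3)n2)cc1` is dimethylamino in place of 4-methylpiperidin-1-yl on an aromatic carbon.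

Among the measured compounds shown here, only one measured step between compounds differing in a single place exists, a 1.1-fold lower number from compound 1 to compound 2 (0.02 log units; within the scatter), and it concerns the furan-2-yl to 3-methylthiophen-2-yl exchange, not the amine. For the measured compounds named here, no measured step covers the exchange of 4-methylpiperidin-1-yl for dimethylamino directly. Still, compound 2 and compound 3 carry different amines. Compound 2 shows 1800 nM, and compound 3 shows 400 nM. Since the exchange at the other position moved little in a 1.1-fold lower number from compound 1 to compound 2 (0.02 log units; within the scatter), most of that gap plausibly belongs to the amine. Compound 4 is therefore expected to move back toward the numbers of compound 1 and compound 2, an upward step of about a 4.3-fold higher number from compound 3 to compound 4 (0.63 log units; beyond the scatter) in this assay. The estimate for compound 4 is 1700 nM, with a range from 700 nM to 4500 nM.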

Compound 4, half-maximal inhibitory concentration: 900 nM
The estimate for compound 4 lay 1.9-fold (0.28 log units) above the measured number, and the stated range covers the measured number.
By their numbers in this assay, from the lowest: compound 3; then compounds 4, 2 and 1 (each within the scatter of the next, the first and the last beyond it).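

In this assay, the exchange at the position para to a large group can now be read directly: dimethylamino in place of 4-methylpiperidin-1-yl gives a modest step beyond the scatter (a 2.3-fold higher number from compound 3 to compound 4 (0.35 log units; beyond the scatter)), so the group with the six-membered ring goes with the stronger inhibition in this pair. On the other side of the core, thiophen-2-yl in place of furan-2-yl also gives a modest step beyond the scatter (a 2.1-fold lower number from compound 1 to compound 4 (0.32 log units; beyond the scatter)), whereas hydrogen in place of the methyl of the 3-methylthiophen-2-yl group stays within it (a 2.0-fold lower number from compound 2 to compound 4 (0.30 log units; within the scatter)), so that methyl makes no clear difference here. Nothing available explains why either exchange shifts the number.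

From the compounds shown here alone, it remains open whether the gain follows from the ring itself or from its methyl, which a plain piperidin-1-yl group would separate, and whether a morpholin-4-yl or piperazin-1-yl group would behave like 4-methylpiperidin-1-yl. How a longer chain on the amine nitrogen or a carboxylic acid on the thiophene would read in this assay is also unknown.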